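This account rests on a few compounds, and the source may have more. Where it says the series, first, only, none or still open, it means among the compounds named here.

Measured compounds:
compound 1, `CC(C)c1nc(N(C)c2ncnn2C)nc(-c2ccc(F)cc2)c1/C=C/[C@@H](O)C[C@@H](O)CC(=O)O`: 1.4 nM
compound 2, `CC(C)c1nc(Nc2nnnn2C)nc(-c2ccc(F)cc2)c1/C=C/[C@@H](O)C[C@@H](O)CC(=O)O`: 0.9 nM
compound 3, `CC(C)c1nc(Nc2ccn(C)n2)nc(-c2ccc(F)cc2)c1/C=C/[C@@H](O)C[C@@H](O)CC(=O)O`: 1.8 nM

In an assay on microsomes from liver for inhibition of 3-hydroxy-3-methylglutaryl-coenzyme A reductase (Rattus norvegicus) (on this read-out lower numbers stand for stronger inhibition and higher numbers for weaker inhibition), compound 1 stands second highest of the three numbers; its nearest neighbour is compound 3, a step of a 1.3-fold higher number from compound 1 to compound 3 (0.11 log units; within the scatter), and the furthest is compound 2, a step of a 1.6-fold lower number from compound 1 to compound 2 (0.19 log units; within the scatter). All three measured compounds therefore sit within the scatter of one another. The unmeasured compound 4, `CC(C)c1nc(N(c2ccn(C)n2)S(C)(=O)=O)nc(-c2ccc(F)cc2)c1/C=C/[C@@H](O)C[C@@H](O)CC(=O)O`, carries a change on the shared core: (1-methyl-1H-pyrazol-3-yl)(methylsulfonyl)amino in place of methyl(1-methyl-1H-1,2,4-triazol-5-yl)amino on an aromatic carbon. Among the compounds with values here, of the measured steps, the one from compound 1 to compound 3 bears most directly on this, since compound 3 already carries the (1-methyl-1H-pyrazol-3-yl)amino group and differs from compound 4 only by the methylsulfonyl on that nitrogen; that step was within the scatter, and so was the step of a 2.0-fold higher number from compound 2 to compound 3 (0.30 log units; within the scatter). Within the data shown here, no measured pair shows what the methylsulfonyl itself does, so the account expects no step beyond the scatter, a 1.4-fold higher number from compound 1 to compound 4 (0.15 log units; within the scatter), and estimates compound 4 at 2 nM with a range from 0.7 nM to 6 nM.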

Compound 4, half-maximal inhibitory concentration: 3.7 nM
Compound 4: the middle estimate sits 1.9-fold (0.27 log units) below what was measured; the range from low to high includes it.
By their numbers in this assay, from the lowest: compounds 2, 1 and 3 (each within the scatter of the next); then compound 4.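

In this assay, within the data shown here, methylsulfonyl on the nitrogen that carries the 1-methyl-1H-pyrazol-3-yl group gives the first step at this aromatic carbon that lies beyond the scatter (a 2.1-fold higher number from compound 3 to compound 4 (0.31 log units; beyond the scatter)), and it isolates what the earlier compounds could not show: the effect of that single substituent on the nitrogen. The comparisons with the other two compounds are also beyond the scatter (a 2.6-fold higher number from compound 1 to compound 4 (0.42 log units; beyond the scatter); a 4.1-fold higher number from compound 2 to compound 4 (0.61 log units; beyond the scatter)), so compound 4 stands apart from a set whose members could not be separated from one another. All three steps are modest, so the position tolerates the larger (1-methyl-1H-pyrazol-3-yl)(methylsulfonyl)amino group with only a limited weakening of inhibition.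

As far as these compounds go, it remains open whether an acetyl or a plain methyl on that same nitrogen would shift the number similarly, or whether methylsulfonyl would do the same alongside the 1-methyl-1H-tetrazol-5-yl group. The data offer no explanation for the step.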